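Replacing the Outer Aryl Amine with an Aryl Ring

This account rests on a few compounds, and the source may have more. Where it says the series, first, only, none or still open, it means among the compounds named here.

Compound 2 `COc1cc(Cl)cc(-c2nn(-c3cccc(NC(=O)Nc4ccc(Cl)c(C(F)(F)F)c4)c3)cc2-c2ccncc2)c1` was tested in a functional assay on OVCAR-4 cells (Homo sapiens) for inhibition, read by sulforhodamine B assay, with a stated time of 48 h, tested at 10 uM (on this read-out higher numbers stand for a weaker effect at the one concentration tested and lower numbers for a stronger effect), where compound 2 gives 16.6%. Among the three measured compounds it stands second highest. Compound 3 `COc1cc(Cl)cc(-c2nn(-c3cccc(NC(=O)Nc4cc(C(F)(F)F)cc(C(F)(F)F)c4)c3)cc2-c2ccncc2)c1` gives 11.9%, a number within the scatter of compound 2, so the two cannot be ranked against each other. Compound 1 `O=C(Nc1cccc(-n2cc(-c3ccncc3)c(-c3cc(O)cc(Cl)c3)n2)c1)Nc1ccc(Cl)c(C(F)(F)F)c1` gives 31.6%, a weaker effect in this assay than compound 2. Within the data shown here, the only measured step, a number 15 percentage points lower from compound 1 to compound 2 (beyond the scatter), concerns a methyl in place of hydrogen on an oxygen on an aromatic ring, a change elsewhere in the molecule. Compound 4 `COc1cc(Cl)cc(-c2nn(-c3cccc(NC(=O)c4cccc(C(F)(F)F)c4)c3)cc2-c2ccncc2)c1` differs from compound 2 by 3-(trifluoromethyl)phenyl in place of (4-chloro-3-(trifluoromethyl)phenyl)amino on a carbonyl carbon. Among the measured compounds shown here, no measured step bears on this place: compound 2 and compound 3 differ only within the group that leaves here, and their values lie within the scatter of each other. With no measured guide and a change that removes a hydrogen-bond donor, the step expected here is a number 13.4 percentage points higher from compound 2 to compound 4 (beyond the scatter). Compound 4 is therefore estimated to give 30%, within a range from 10% to 60%.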

Compound 4, a percentage reported as activity, at one concentration (the size of the read-out at that concentration, not a potency): 71.8%
Beside the measured number, compound 4's estimate is 41.8 percentage points below it; the measured number lies above the stated range.
By their numbers in this assay, from the lowest: compounds 3 and 2 (each within the scatter of the next); then compound 1; then compound 4.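

Among these compounds, the step in this assay is a number 55.2 percentage points higher from compound 2 to compound 4 (beyond the scatter) and marks a large loss of effect, so this place on the carbonyl carbon matters far more than the earlier compounds could show. Compound 2 and compound 3 both keep the amino nitrogen and differ only in the groups on its aromatic ring, whereas compound 4 gives up that nitrogen with its hydrogen-bond donor and also the chlorine. Nothing measured here explains the loss of effect.

Among the compounds shown here, the single step cannot tell whether the nitrogen or the chlorine accounts for the change. From the compounds shown here alone, that question remains open for 4-chloro-3-(trifluoromethyl)phenyl placed directly on the carbonyl carbon, which would keep the chlorine, and for a methylene group in the position of the amino nitrogen.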